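A few compounds are considered here, and "the series" means these few. Any claim that something is new, unique, unknown or untested is made for them only; others in the source may bear on it.

Measured in a functional assay on OVCAR-3 cells (Homo sapiens) for inhibition, read by CCK-8 assay, with a stated time of 72 h, tested at 20 uM; on this read-out lower numbers stand for less inhibition of growth and higher numbers for more inhibition of growth at the one concentration tested:

compound 1 `CC(C)(C)OC(=O)/C=C1/C(=O)N(Cc2ccccc2)c2ccccc21`: 58.9%
compound 2 `Cc1ccc2c(c1)/C(=C\C(=O)OC(C)(C)C)C(=O)N2`: 59.5%
compound 3 `CC(C)(C)OC(=O)/C=C1/C(=O)Nc2c(Cl)cccc21`: 59.3%

Compound 2 gives 59.5% in this assay; the numbers for compound 1 and compound 3 lie within the scatter of it, so the three measured compounds cannot be told apart on this read-out. For the measured compounds named here, no step between two measured compounds that differ in one place is available, so nothing shows what a single change at the core does.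

Compound 4 `CC(C)(C)OC(=O)/C=C1/C(=O)Nc2ccc([N+](=O)[O-])cc21` differs from compound 2 by nitro in place of methyl on an aromatic carbon. With the three measured numbers all alike, the expected step of a number 1.5 percentage points lower from compound 2 to compound 4 (within the scatter) is none beyond the scatter. Compound 4 is therefore expected to give about 58% in this assay, within 44% to 70%.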

Compound 4, percent growth inhibition at one concentration: 55.6%
Compound 4: middle estimate off by 2.4 percentage points, on the high side; the measured number falls inside the stated range.
By their numbers in this assay, from the lowest: compounds 4, 1, 3 and 2 (each within the scatter of the next).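

In this assay the series now has its first step in one place, a number 3.9 percentage points lower from compound 2 to compound 4 (within the scatter) for nitro in place of methyl on an aromatic carbon. At this place the two groups cannot be told apart on this read-out, although nitro carries more heavy atoms and hydrogen-bond acceptors than methyl. No measurement at hand bears on why the exchange gives no step beyond the scatter.

From the compounds shown here alone, whether an amine or a carboxylic acid on this aromatic carbon would give a step beyond the scatter remains open.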